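Weighing a Dimethylcarbamoyl Addition Against Hepatocyte Clearance

The source may report more compounds than this note shows. Statements on the series, on what has been measured and on what is new or still open speak of the compounds shown alone.

The study covers three measured compounds: compound 1 `Cc1ncccc1-c1cnc(NCc2c(F)ccc3c2CCO3)c2cn[nH]c(=O)c12`, compound 2 `CN(c1ccn(C)n1)c1cnc(NCc2c(F)ccc3c2CCO3)n2cnnc12` and compound 3 `O=C1CC2(CC2)CN1c1cnc(NCc2c(F)ccc3c2CCO3)n2cnnc12`. In an ADME assay on cells (Hepatocyte, Homo sapiens) for metabolic stability, read by HPLC, with a stated time of 30 min, tested at 1 uM (on this read-out lower numbers stand for slow clearance and higher numbers for fast clearance), compound 1 gives 4.6 uL/min, the highest of the two numbers reported. Compound 3 gives 3.5 uL/min, which lies within the usual scatter of compound 1, so no order between these two can be claimed. For compound 2 the assay returns only a limit, < 1 uL/min. Of the three values, (the limit of < 1 uL/min in this assay, at which 1 of the 3 values shown sits).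

Among the compounds with values here, only one step between compounds differing in a single place is available: an at least 3.5-fold higher number from compound 2 to compound 3 (0.54 log units; beyond the scatter). It swaps one ring-bearing group for another on a different core and does not involve the change now in question.

Compound 4 `Cc1nc(C(=O)N(C)C)ccc1-c1cnc(NCc2c(F)ccc3c2CCO3)c2cn[nH]c(=O)c12` is not yet measured. It differs from compound 1 by dimethylcarbamoyl in place of hydrogen on an aromatic carbon. Within the data shown here, no measured compound carries a dimethylcarbamoyl group, so the measured step offers no direct guide. Since compound 1 and compound 3 carry quite different groups yet sit within the scatter of each other, the account expects no change beyond the scatter, giving an expected step of a 1.3-fold lower number from compound 1 to compound 4 (0.12 log units; within the scatter). Compound 4 is therefore estimated at 3.5 uL/min, within a range from 1.5 uL/min to 8 uL/min.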

Compound 4, intrinsic clearance in a liver preparation (reported as CLH), per the amount of preparation that the assay uses: < 1.3 uL/min
Compound 4 was reported as a limit (the forecaster's own chance of this, stated with the estimate: 15%); middle value at least 2.6-fold (0.43 log units) from the limit.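

Dimethylcarbamoyl on an aromatic carbon of the six-membered aromatic ring with 1 nitrogen, next to the ring nitrogen, meta to a methyl group and para to a large group, gives in this assay an at least 3.5-fold lower number from compound 1 to compound 4 (0.54 log units; beyond the scatter) and so moves the read-out beyond the scatter. Within the data shown here, this is the first reading of a change at this place, since the earlier step from compound 2 to compound 3 concerned a different group on a different core and said nothing about this ring of compound 1. The size of the new step is a bound and not an exact figure, because compound 4 is reported only as a limit: the limit of < 1.3 uL/min in this assay, at which 1 of the 4 values shown sits.

The compounds shown leave open whether the lower number belongs to dimethylcarbamoyl itself or would also follow from another group on the same aromatic carbon, such as an amine, a carboxylic acid or a longer chain. They also leave open where the true value of compound 4 lies, and whether dimethylcarbamoyl would shift the read-out in the same direction on any other core.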